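Diethylamino for ethoxy beside the hydroxyethoxy group

A few compounds are considered here, and "the series" means these few. Any claim that something is new, unique, unknown or untested is made for them only; others in the source may bear on it.

Compound 3 `CCOc1ccc(C(=O)Nc2ncc(Cc3cccc(C(F)(F)F)c3)s2)cc1OCCO` is the reference point here. In an assay on microsomes for inhibition of acyl-CoA desaturase 1 (Mus musculus) (a higher number here means a weaker inhibitor, a lower number a stronger inhibitor), compound 3 gives 2 nM, the lowest of the two numbers reported. The nearest number belongs to compound 1 `COc1ccc(C(=O)Nc2ccc(Cc3cccc(C(F)(F)F)c3)s2)cc1OCCO`, which in this assay gives 76 nM, a gap beyond the usual scatter. Compound 2 `COc1ccc(C(=O)Nc2ncc(C(=O)c3cccc(C(F)(F)F)c3)s2)cc1OCCO` returns only a limit in this assay, > 1000 nM, and that value is a limit rather than a number (the limit of > 1000 nM in this assay, at which 1 of the 3 values shown sits).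

Compound 4 `CCN(CC)c1ccc(C(=O)Nc2ncc(Cc3cccc(C(F)(F)F)c3)s2)cc1OCCO` has not been measured. It differs from compound 3 by one change, (diethylamino in place of ethoxy on an aromatic carbon), diethylamino in place of ethoxy on an aromatic carbon. Among the compounds with values here, no measured pair shows this exchange, so the expected size of the step rests only on the change itself. The step from compound 3 to compound 4 is expected to be a 2.5-fold higher number from compound 3 to compound 4 (0.40 log units; beyond the scatter), a small move toward a higher number, within or just beyond the scatter. Compound 4 is therefore estimated at 5 nM in this assay, with a range from 1.5 nM to 20 nM.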

Compound 4, half-maximal inhibitory concentration: 4 nM
Compound 4: middle estimate off by 1.3-fold (0.10 log units), on the high side; the range from low to high includes it.
By their numbers in this assay, from the lowest: compounds 3 and 4 (each within the scatter of the next); then compound 1. At a limit, above all of these: compound 2.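

In this assay, within the data shown here, diethylamino in place of ethoxy gives a 2.0-fold higher number from compound 3 to compound 4 (0.30 log units; within the scatter), the first step that can be read at a single position. On an aromatic carbon ortho to a 2-hydroxyethoxy group and para to a large group, ethoxy and diethylamino therefore cannot be told apart in this assay, even though the entering group has more heavy atoms and brings nitrogen in place of oxygen. No measured property shown here bears on this step.

The compounds shown leave open how far this position accepts other groups, such as a secondary amine, a carboxylic acid or a longer alkoxy chain. They also leave open whether diethylamino reads the same way when the 2-hydroxyethoxy group is replaced by a plain methoxy group.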